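This account rests on a few compounds, and the source may have more. Where it says the series, first, only, none or still open, it means among the compounds named here.

In a functional assay on PC-3 cells (Homo sapiens) for antiproliferative activity (a higher number here means a weaker inhibitor, a lower number a stronger inhibitor), compound 1 `Nc1nc(=O)n([C@H]2C=C[C@@H](CO)O2)cc1Br` gives > 100000 nM, which is a limit of the assay and not a number. Compound 2 `O=c1[nH]c(=O)n([C@@H]2C=C[C@@H](CO)O2)cc1F` gives > 100000 nM, which is also a limit. The evidence so far is therefore only (the limit of > 100000 nM in this assay, at which 2 of the 2 values shown sit). Compound 3 `O=c1[nH]c(=O)n([C@@H]2C=C[C@H](CO)O2)cc1F` has the same atoms and bonds as compound 2 and differs only in configuration as drawn: the two compounds have the same atoms and bonds and differ only in configuration as drawn: 1 of 2 stereo elements differ; a stereocentre at a saturated ring carbon is drawn S in compound 2 and R in compound 3. Among the measured compounds shown here, no measured step is available as a guide, so no change beyond the usual scatter is expected in this assay. The expected size of the change is a number no higher from compound 2 to compound 3 (the limit leaves the size open). Compound 3 is estimated at 100000 nM, with an expected range from 40000 nM to 200000 nM.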

Compound 3, half-maximal inhibitory concentration: 83400 nM
Beside the measured number, compound 3's estimate is 1.2-fold (0.08 log units) above it; measured number inside the range.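

In this assay, among the compounds shown here, compound 3 gives 83400 nM, the first real number here rather than a limit. Changing only the stereocentre at a saturated ring carbon from S to R gives an at least 1.1-fold lower number from compound 2 to compound 3 (0.07 log units; that floor lies within the scatter). The value of compound 2 is a limit, so the true size of this step stays open, and configuration is not shown to matter beyond the scatter.

The compounds shown leave open whether changing the other stereo element would alter the result. They also leave open whether a carboxylic acid or a longer chain on the shared core would give a much lower number.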